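Notes on the Step from Compound 1 to Compound 3

The compounds below may be only part of what the source reports. "The series", "measured", "known", "first", "only" and "open" are said of these compounds alone.

Measured so far:
compound 1 `CN(Cc1ccc(C(=O)O)cc1)c1ccc(OCc2c(-c3c(Cl)cccc3Cl)noc2C2CC2)nc1C(F)(F)F`: 60%
compound 2 `CN(Cc1ccc(C(=O)NCCS(=O)(=O)O)cc1)c1ccc(OCc2c(-c3c(Cl)cccc3Cl)noc2C2CC2)nc1C(F)(F)F`: 49%

In a functional assay on HEK293 cells for agonist activity at Bile acid receptor (Homo sapiens), read by a luciferase reporter (on this read-out higher numbers stand for larger maximal responses and lower numbers for smaller maximal responses), compound 1 gives 60%, the higher of the two numbers. Compound 2 gives 49%. Among the measured compounds shown here, the one measured step is a number 11 percentage points lower from compound 1 to compound 2 (beyond the scatter), and it concerns the carbonyl end only.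

Compound 3 `CC(Oc1cccc(C(=O)O)c1)c1ccc(OCc2c(-c3c(Cl)cccc3Cl)noc2C2CC2)nc1C(F)(F)F` differs from compound 1 by 1-(3-carboxyphenoxy)ethyl in place of (4-carboxybenzyl)(methyl)amino on an aromatic carbon. For the measured compounds named here, no measured step touches this position, so the change is untested and the direction is open; a modest step either way is plausible. Compound 3 is therefore expected to give about 50%, between 30% and 70%, which means an estimated step of a number 10 percentage points lower from compound 1 to compound 3 (within the scatter).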

Compound 3, largest response reached (reported as efficacy), in percent of the reference or control that the assay uses: 49%
Compound 3: the middle estimate sits 1 percentage points above what was measured; the range from low to high includes it.
By their numbers in this assay, from the lowest: compounds 2 and 3 (each within the scatter of the next); then compound 1.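

In this assay, 1-(3-carboxyphenoxy)ethyl in place of (4-carboxybenzyl)(methyl)amino, on the aromatic carbon ortho to a trifluoromethyl group, gives a number 11 percentage points lower from compound 1 to compound 3 (beyond the scatter). This position therefore responds to change, even though the two groups match in their counts of heavy atoms, hydrogen-bond donors and acceptors. Compound 3 still gives 49% with no nitrogen in this group.

The step bundles the linking atoms, the methyl branch and the place of the carboxylic acid on the ring, so their shares stay unseparated. How a tetrazole in place of that carboxylic acid would read also stays open, and nothing available explains the step.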